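A few compounds are considered here, and "the series" means these few. Any claim that something is new, unique, unknown or untested is made for them only; others in the source may bear on it.

Measured so far:
compound 1 `CC(C)(O)C(CCC/C=C(\c1ccccc1)c1cccnc1)C(=O)O`, 42 nM
compound 2 `O=C(O)CCCC/C=C\c1cccnc1`, 250 nM
compound 3 `CC(C)(CCCC/C=C(/c1ccccc1)c1cccnc1)C(=O)O`, 38 nM

In an assay (Equus caballus) for inhibition of Thromboxane-A synthase (Homo sapiens), using microsomes (on this read-out higher numbers stand for weaker inhibition and lower numbers for stronger inhibition), compound 3 gives the lowest of the three numbers. Compound 1 sits nearest, and its number lies within the usual scatter of compound 3, so the two cannot be ordered. Compound 2, which carries only the pyridyl alkene without the phenyl group and with a shorter acid chain, gives a number beyond the scatter above compound 3.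

Compound 4 `O=C(O)CCCCCCCCC/C=C(/c1ccccc1)c1cccnc1` has not yet been measured. It differs from compound 3 in one place: 5-carboxypentyl in place of 1-carboxy-1-methylethyl on a saturated chain carbon, four bonds along the chain from a double-bonded chain carbon. The carboxylic acid thus moves further from the double bond, and the branching at the chain carbon that carried it is gone. Compound 2 shows that a plain chain with the acid at a different distance from the pyridine sits clearly higher than compound 3 and compound 1, but compound 2 also lacks the phenyl group, so its number cannot be laid solely at the chain. The step from compound 3 to compound 4 is therefore expected to go upward, to a weaker inhibition, by an amount somewhat beyond the scatter, as a 3.9-fold higher number from compound 3 to compound 4 (0.60 log units; beyond the scatter). Compound 4 is expected to give 150 nM in this assay, within a range from 40 nM to 600 nM.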

Compound 4, half-maximal inhibitory concentration: 520 nM
Beside the measured number, compound 4's estimate is 3.5-fold (0.54 log units) below it; the measured number falls inside the stated range.
By their numbers in this assay, from the lowest: compounds 3 and 1 (each within the scatter of the next); then compound 2; then compound 4.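

In this assay, putting 5-carboxypentyl in place of 1-carboxy-1-methylethyl on a saturated chain carbon, four bonds along the chain from a double-bonded chain carbon, gives a 14-fold higher number from compound 3 to compound 4 (1.14 log units; beyond the scatter) and counts as a large step. For the compounds shown here, this is the first comparison in the set that changes this position alone: the rest of the structure stays the same, so the rise in the number belongs to this exchange of groups and shows that the position does not accept every chain ending in a carboxylic acid equally. Nothing measured here explains why the number rises.

The single step combines a longer chain with the loss of the branching, and the compounds shown do not separate the two: an unbranched carboxyalkyl chain of the length in compound 3, or a longer chain keeping the two methyl groups at the carbon next to the carboxylic acid, would tell them apart. From the compounds shown here alone, it also remains open whether a shorter chain, or an ester or amide in place of the carboxylic acid, would hold the number at this position.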